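A few compounds are considered here, and "the series" means these few. Any claim that something is new, unique, unknown or untested is made for them only; others in the source may bear on it.

In an ADME assay on L6 cells (Rattus norvegicus) for cytotoxicity (a higher number here means a weaker inhibitor, a lower number a stronger inhibitor), compound 1 (`O=[N+]([O-])c1ncn(CCCNS(=O)(=O)c2ccc(C(F)(F)F)cc2)n1`) gives 235000 nM. For compound 2 (`Cc1ccc(S(=O)(=O)NCCCn2cnc([N+](=O)[O-])n2)cc1`), the reading of > 307000 nM is a limit of the assay, not a number. Compound 3 (`Cn1ccnc1S(=O)(=O)NCCCn1cnc([N+](=O)[O-])n1`) carries a new group on the sulfonyl sulfur: 1-methyl-1H-imidazol-2-yl in place of 4-methylphenyl, (1-methyl-1H-imidazol-2-yl in place of 4-methylphenyl on a sulfonyl sulfur). Within the data shown here, only one measured step bears on this, and only loosely, since it has methyl in place of trifluoromethyl on an aromatic carbon: an at least 1.3-fold higher number from compound 1 to compound 2 (0.11 log units; that floor lies within the scatter). No change beyond the scatter is therefore expected, and the estimated step is a step that the limit leaves unreadable from compound 2 to compound 3. For compound 3, the expected value is 310000 nM, with an estimated range of 150000 nM to 450000 nM.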

Compound 3, half-maximal inhibitory concentration: > 317000 nM
Compound 3: a limit, no number; the forecaster's own chance of this, stated with the estimate: 70%; at least 1.0-fold (0.00 log units) between middle value and limit.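

Compound 2 and compound 3 each give only a limit, not a number, in this assay, so the step between them cannot be read. The compounds shown leave open whether 1-methyl-1H-imidazol-2-yl in place of 4-methylphenyl on a sulfonyl sulfur changes the reading at all.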